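Compound 3: 4-carbamoylcyclohexyl in place of oxan-4-yl

The source may hold more compounds than are shown below. What is called first, only, known or untested is meant among the compounds shown, and "the series" means these compounds.

For the measured compounds named here, in a physicochemical assay for lipophilicity, using the shake flask method, at pH 7.4 (a lower number here means a more polar compound, a higher number a more lipophilic compound), compound 2 `CN(C)[C@H]1CC[C@H](Nc2ncnn3ccc(C4CCOCC4)c23)CC1` gives 0.5, the higher of the two numbers measured so far. Compound 1 `CN(C)[C@H]1CC[C@H](Nc2ncnn3ccc([C@H]4CC[C@@H](C(N)=O)CC4)c23)CC1` gives 0.1 in this assay. Compound 3 `CN(C)[C@H]1CC[C@H](Nc2ncnn3ccc([C@H]4CC[C@H](C(N)=O)CC4)c23)CC1` has 4-carbamoylcyclohexyl in place of the oxan-4-yl of compound 2, on an aromatic carbon of the shared core: 4-carbamoylcyclohexyl in place of oxan-4-yl on an aromatic carbon.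

Going by the values given here, one measured step bears on this change: a number 0.40 log units higher from compound 1 to compound 2 (beyond the scatter), which is modest, beyond the scatter and runs the opposite way. Among the compounds with values here, compound 3 carries the same named group as compound 1 but differs from it at the defined stereocentres, and no measurement yet shows what that difference does. A modest fall of similar size is therefore expected, a number 0.40 log units lower from compound 2 to compound 3 (beyond the scatter). The estimated value for compound 3 is 0.1, with an expected range from -0.2 to 0.4.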

Compound 3, distribution coefficient: 0.2
Estimate against measurement, compound 3: 0.10 log units below; the measured number falls inside the stated range.
By their numbers in this assay, from the lowest: compounds 1, 3 and 2 (each within the scatter of the next, the first and the last beyond it).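

In this assay, the two drawn forms of 4-carbamoylcyclohexyl on this aromatic carbon can now be set side by side, and the change gives a number 0.10 log units higher from compound 1 to compound 3 (within the scatter), so configuration shows no separation here. Exchanging oxan-4-yl for the form in compound 3 gives a number 0.30 log units lower from compound 2 to compound 3 (within the scatter), whereas the exchange involving the form in compound 1 gave a number 0.40 log units higher from compound 1 to compound 2 (beyond the scatter), so the two readings of this swap fall on opposite sides of the scatter. The first comparison can be read as an effect of configuration alone because of one fact: the fact that compounds 1 and 3 differ only in the configuration as drawn

Still open, as far as these compounds go, is whether a carboxylic acid or an amine in place of the carbamoyl group would give a number beyond the scatter from compound 1 and compound 3. Also open, from the compounds shown here alone, is whether configuration at this ring stays without effect when another group replaces the carbamoyl.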